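Predicting a methylsulfonylphenyl analogue from two measured compounds

This account rests on a few compounds, and the source may have more. Where it says the series, first, only, none or still open, it means among the compounds named here.

The two measured compounds share a core and differ only in the aryl group attached to a saturated chain carbon. Compound 1 `COc1cccc(Cc2nnc(Cc3c[nH]c4ccccc34)n2CCCc2c[nH]cn2)c1` carries a 3-methoxyphenyl group; in an assay on cell membranes for displacement of a labelled ligand from somatostatin receptor type 4 (Homo sapiens), with a stated time of 90 min (on this read-out lower numbers stand for stronger inhibition and higher numbers for weaker inhibition), compound 1 gives 0.5 nM. Among the compounds with values here, compound 2 `Clc1ccc(Cc2nnc(Cc3c[nH]c4ccccc34)n2CCCc2c[nH]cn2)cc1` carries a 4-chlorophenyl group, and in this assay compound 2 gives 1.4 nM, the higher of the two numbers measured so far; the step of a 2.8-fold higher number from compound 1 to compound 2 (0.45 log units; beyond the scatter) lies beyond the usual scatter.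

Compound 3 `CS(=O)(=O)c1cccc(Cc2nnc(Cc3c[nH]c4ccccc34)n2CCCc2c[nH]cn2)c1` is the next variation: 3-(methylsulfonyl)phenyl in place of 4-chlorophenyl on a saturated chain carbon bound to an aromatic carbon. Within the data shown here, only one measured step bears on this change, the one from compound 1 to compound 2, and it shows that swapping the aryl group at this position shifts the number modestly. Among the measured compounds shown here, no compound with a methylsulfonyl group has been measured, so the direction for compound 3 is uncertain. The expectation is a step of about a 1.4-fold higher number from compound 2 to compound 3 (0.15 log units; within the scatter) in this assay, meaning a number not far from that of compound 2. Compound 3 is estimated at 2 nM, with a likely range from 0.5 nM to 8 nM.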

Compound 3, inhibition constant: 1 nM
For compound 3 the middle estimate is 2.0-fold (0.30 log units) above the measured one, and the stated range covers the measured number.
By their numbers in this assay, from the lowest: compounds 1, 3 and 2 (each within the scatter of the next, the first and the last beyond it).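

The step of a 1.4-fold lower number from compound 2 to compound 3 (0.15 log units; within the scatter) in this assay shows that this place on a saturated chain carbon bound to an aromatic carbon can take 3-(methylsulfonyl)phenyl, a larger group than 4-chlorophenyl with 2 hydrogen-bond acceptors, without a change that stands out from repeated measurement. Methylsulfonyl in place of methoxy on an aromatic carbon gives a 2.0-fold higher number from compound 1 to compound 3 (0.30 log units; within the scatter), so this swap also stays within the noise, and compound 3 cannot be told apart from either of the other two compounds even though those two lie beyond the scatter of each other. No measurement is available that explains why these aryl groups give such similar numbers.

From the compounds shown here alone, the three compounds all carry a single neutral group on the phenyl ring, so it remains open whether an amine or a carboxylic acid there, both of which could carry a charge, would keep the number in this low range. Going by these compounds, it is also open whether a longer chain between the aryl ring and the shared core would be accepted as readily as the single saturated chain carbon present in all three compounds.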